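This account rests on a few compounds, and the source may have more. Where it says the series, first, only, none or still open, it means among the compounds named here.

Working notes on the series.

Within the data shown here, compound 3 `O=C(/C=C/c1cn([C@@H]2C[C@@H](C(=O)O)N(Cc3ccccc3)C2)nn1)NO` is the only member with a number in an assay on Sf9 cells for inhibition of histone deacetylase 11 (Homo sapiens), read by fluorescence, tested at 0.5 uM; on this read-out higher numbers stand for more inhibition at the one concentration tested (going by the name of the read-out) and lower numbers for less inhibition: compound 3 gives 12%. Compound 1 `O=C(NO)c1cccc(-c2cn([C@H]3C[C@H](C(=O)O)N(Cc4ccccc4)C3)nn2)c1` gives only a limit of this assay, < 10%. Compound 2 `O=C(/C=C/c1cn([C@@H]2C[C@H](C(=O)O)N(Cc3ccccc3)C2)nn1)NO` likewise gives only a limit, < 10%. Among the measured compounds shown here, the one measured step, a number at least 2 percentage points higher from compound 2 to compound 3 (that floor lies within the scatter), rests on the limit of < 10% in this assay, at which 2 of the 3 values shown sit, and on (the fact that compounds 2 and 3 differ only in the configuration as drawn), and stays within the scatter.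

Compound 4 `O=C(/C=C/c1cn([C@H]2C[C@H](C(=O)O)N(Cc3ccccc3)C2)nn1)NO` differs from compound 3 by the two compounds have the same atoms and bonds and differ only in configuration as drawn: 2 of 3 stereo elements differ; a stereocentre at a saturated ring carbon is drawn R in compound 3 and S in compound 4; a stereocentre at a saturated ring carbon is drawn S in compound 3 and R in compound 4. For the measured compounds named here, the step from compound 2 to compound 3 is the only guide, and it changed configuration alone without moving beyond the scatter. No step beyond the scatter is therefore expected in this assay for compound 4: a number 2 percentage points lower from compound 3 to compound 4 (within the scatter). Compound 4 is estimated at 10%, between 0% and 22%.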

Compound 4, a percentage reported as inhibition, at one concentration (the size of the read-out at that concentration, not a potency): 14%
Compound 4: middle estimate off by 4 percentage points, on the low side, within the range that was stated.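

In this assay, reversing both stereocentres at saturated ring carbons together gives a number 2 percentage points higher from compound 3 to compound 4 (within the scatter), so even this double change of configuration produces no step beyond the scatter. Reversing only one of them gives a number at least 4 percentage points higher from compound 2 to compound 4 (that floor lies within the scatter), and 2-(hydroxycarbamoyl)ethenyl in place of 3-(hydroxycarbamoyl)phenyl gives a number at least 4 percentage points higher from compound 1 to compound 4 (that floor lies within the scatter). Both of these floors lie within the scatter and rest on a limit of the assay: the limit of < 10% in this assay, at which 2 of the 4 values shown sit.

As far as these compounds go, whether a methyl ester or a primary amide in place of the carboxylic acid would give a step beyond the scatter stays open.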